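Swapping chloro for dimethylamino on a long chain

The compounds below may be only part of what the source reports. "The series", "measured", "known", "first", "only" and "open" are said of these compounds alone.

In a functional assay on SW480 cells (Homo sapiens) for antiproliferative activity, read by MTT assay, with a stated time of 48 h (on this read-out higher numbers stand for weaker inhibition and lower numbers for stronger inhibition), compound 1 (`CCCCCCCC(CCO)n1cnc2c(N(C)C)ncnc21`) shows > 50000 nM as a limit, not a number. Compound 2 (`CCCCCCCCCC(CCO)n1cnc2c(N(C)C)ncnc21`) gives 12200 nM and compound 3 (`CCCCCCCCCCC(CCO)n1cnc2c(Cl)ncnc21`) gives 3160 nM as the lower of these two numbers. Compound 4 (`CCCCCCCCCCC(CCO)n1cnc2c(N(C)C)ncnc21`) keeps the chain of compound 3 but has dimethylamino in place of chloro on an aromatic carbon. Among the measured compounds shown here, no measured step makes this swap. Lengthening the chain gave an at least 4.0-fold lower number from compound 1 to compound 2 (0.61 log units; beyond the scatter) among dimethylamino compounds. The closest guide is therefore compound 2 at 12200 nM with the same dimethylamino group and a shorter chain than compound 4. The expected change is a 2.5-fold higher number from compound 3 to compound 4 (0.40 log units; beyond the scatter) as a modest rise beyond the scatter. Compound 4 is expected at 8000 nM (range 3500 nM to 20000 nM).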

Compound 4, half-maximal inhibitory concentration: 3320 nM
Compound 4: middle estimate off by 2.4-fold (0.38 log units), on the high side; the measured number lies below the stated range.
By their numbers in this assay, from the lowest: compounds 3 and 4 (each within the scatter of the next); then compound 2. At a limit, above all of these: compound 1.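

In this assay, the swap at this position gives a 1.1-fold higher number from compound 3 to compound 4 (0.02 log units; within the scatter), so with this chain, chloro and dimethylamino cannot be told apart. Among the dimethylamino compounds, the differences follow the chain instead: a 3.7-fold lower number from compound 2 to compound 4 (0.57 log units; beyond the scatter), and an at least 15-fold lower number from compound 1 to compound 4 (1.17 log units; beyond the scatter). The last of these steps rests on a limit for compound 1, not a number: the limit of > 50000 nM in this assay, at which 1 of the 4 values shown sits.

From the compounds shown here alone, whether morpholine or methoxy on the same aromatic carbon would also match chloro stays open. So does whether a longer chain than that of compound 4 would lower the number further.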